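Shortening the Long Chain of Compound 2

This account rests on a few compounds, and the source may have more. Where it says the series, first, only, none or still open, it means among the compounds named here.

In a functional assay on HepG2 cells (Homo sapiens) for antiproliferative activity, read by MTT assay, with a stated time of 48 h (on this read-out higher numbers stand for weaker inhibition of growth and lower numbers for stronger inhibition of growth), compound 1 `CCN(Cc1ccc(C(=O)NO)cc1)c1ncc(-c2ccc(C)cc2)s1` gives 1120 nM, while compound 2 `Cc1ccc(OCCCCN(Cc2ccc(C(=O)NO)cc2)c2ncc(-c3ccc(C)cc3)s2)cc1` gives 11000 nM, the higher of the two numbers and so the weaker inhibition of growth. Compound 3 `CCCCCCN(Cc1ccc(C(=O)NO)cc1)c1ncc(-c2ccc(C)cc2)s1` has not yet been measured. It differs from compound 2 by ethyl in place of 4-methylphenoxy on a saturated chain carbon, four bonds along the chain from a nitrogen on an aromatic ring. Among the compounds with values here, only one measured step bears on this change: a 9.8-fold higher number from compound 1 to compound 2 (0.99 log units; beyond the scatter), which placed 2-(4-methylphenoxy)ethyl on the chain and lies beyond the scatter. Compound 3 gives back part of that addition, so only a partial return towards the lower number is expected. The expected step is a 3.1-fold lower number from compound 2 to compound 3 (0.50 log units; beyond the scatter), smaller than the measured one. For compound 3 the estimate is 3500 nM, with an expected range of 1200 nM to 10000 nM.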

Compound 3, concentration for 50% growth inhibition: 7420 nM
For compound 3 the middle estimate is 2.1-fold (0.33 log units) below the measured one, within the range that was stated.
By their numbers in this assay, from the lowest: compound 1; then compounds 3 and 2 (each within the scatter of the next).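

In this assay, ethyl in place of 4-methylphenoxy gives a 1.5-fold lower number from compound 2 to compound 3 (0.17 log units; within the scatter), so the two numbers cannot be told apart and the aromatic ring at the end of the chain is not needed for the weak inhibition of growth. Butyl in place of hydrogen on the saturated chain carbon, two bonds along the chain from a nitrogen on an aromatic ring, gives a 6.6-fold higher number from compound 1 to compound 3 (0.82 log units; beyond the scatter), showing that a plain carbon chain at this position is enough to weaken inhibition of growth beyond the scatter. Nothing available explains why the longer chains give higher numbers.

Going by these compounds, it remains open whether a shorter addition, such as methyl, would already raise the number. Also open, on these data alone, is whether an amine or a carboxylic acid at the end of the chain would bring it back towards that of compound 1.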